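Carboxy in place of chloro in a cytotoxic series

The compounds below may be only part of what the source reports. "The series", "measured", "known", "first", "only" and "open" are said of these compounds alone.

In a functional assay on KB-V1 cells (Homo sapiens) for cytotoxicity, read by MTT assay, with a stated time of 72 h (a higher number here means a weaker inhibitor, a lower number a stronger inhibitor), compound 3 `O=C1Nc2ccccc2/C1=N/NC(=S)Nc1ccc(Cl)cc1` gives 4990 nM. Compound 2 `O=C1Nc2ccccc2/C1=N/NC(=S)NCc1ccccc1` gives 7630 nM, and the two stand level, with a 1.5-fold lower number from compound 2 to compound 3 (0.18 log units; within the scatter). Compound 1 `O=C1Nc2ccccc2/C1=N/NC(=S)Nc1cccnc1` reports only a limit of the assay, > 50000 nM.

Compound 4 `O=C1Nc2ccccc2/C1=N/NC(=S)Nc1ccc(C(=O)O)cc1` keeps the core of compound 3 and alters one group: carboxy in place of chloro on an aromatic carbon. The change is carboxy in place of chloro on an aromatic carbon, para to a large group. For the measured compounds named here, no measured step covers this exact exchange, and no measured compound carries a carboxy group. The nearest guides are an at least 10-fold lower number from compound 1 to compound 3 (1.00 log units; beyond the scatter) and an at least 6.5-fold lower number from compound 1 to compound 2 (0.81 log units; beyond the scatter). Both show that the group on the amide-type nitrogen can move the number in this assay beyond the scatter. Losing the chloro is therefore expected to give a step of similar size towards a higher number. The expected step is a 5.0-fold higher number from compound 3 to compound 4 (0.70 log units; beyond the scatter). The estimate for compound 4 is 25000 nM, with an expected range from 8000 nM to 80000 nM.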

Compound 4, half-maximal inhibitory concentration: > 50000 nM
Compound 4 gave a limit, no number; the forecaster's own chance of this, stated with the estimate: 45%; middle value at least 2.0-fold (0.30 log units) from the limit.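

In this assay, replacing chloro with carboxy on this aromatic carbon, para to a large group, gives an at least 10-fold higher number from compound 3 to compound 4 (1.00 log units; beyond the scatter). The earlier compounds shown here showed such a shift only for the group on the amide-type nitrogen, whereas this step shows that a single exchange on the aromatic ring can also move the number beyond the scatter. Compound 4 gives only a limit of the assay, and that limit recurs in this short series: the limit of > 50000 nM in this assay, at which 2 of the 4 values shown sit.

As far as these compounds go, whether a methyl ester, an amine or plain hydrogen at this position would hold the number of compound 3 stays open, and with it whether the step turns on the arrival of carboxy or on the departure of chloro. From the compounds shown here alone, how far compound 4 lies past its limit also stays open.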